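The source may report more compounds than this note shows. Statements on the series, on what has been measured and on what is new or still open speak of the compounds shown alone.

Measured in a physicochemical assay for solubility, read by HPLC, in phosphate buffer, measured as kinetic solubility, with a stated time of 24 h, at 20 degrees C, at pH 7.4, tested at 100 uM; a lower number here means a less soluble compound, a higher number a more soluble compound:
compound 1 `CC(C)n1nc(-c2ccc3oc(N)nc3c2)c2c(=O)[nH]c(N)nc21`: 9200 nM
compound 2 `CNc1nc2c(c(-c3ccc4oc(N)nc4c3)nn2C(C)C)c(=O)[nH]1`: < 1000 nM, which is a limit of the assay and not a number
compound 3 `CC(C)n1nc(-c2ccc3oc(N)nc3c2)c2c(=O)[nH]c(N(C)C)nc21`: 2000 nM

Compound 3 stands lowest of the two numbers shown; its nearest neighbour is compound 1, and the step of a 4.6-fold lower number from compound 1 to compound 3 (0.66 log units; beyond the scatter) puts that gap beyond the scatter. The value of compound 2 sits at the limit of < 1000 nM in this assay, at which 1 of the 3 values shown sits, and gives no number to rank against.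

Compound 4 `Cc1nc2c(c(-c3ccc4oc(N)nc4c3)nn2C(C)C)c(=O)[nH]1` differs from compound 3 by methyl in place of dimethylamino on an aromatic carbon. Among the compounds with values here, no measured step covers this exact change. Within the data shown here, the steps that bear on it are a 4.6-fold lower number from compound 1 to compound 3 (0.66 log units; beyond the scatter), where dimethylamino replaced amino, and an at least 9.2-fold lower number from compound 1 to compound 2 (0.96 log units; beyond the scatter), where methyl replaced hydrogen on a ring nitrogen; both added methyl carbon and both lowered the number. The step of an at least 2.0-fold higher number from compound 2 to compound 3 (0.30 log units; that floor lies within the scatter) rests on a limit and only shows that compound 2 and compound 3 may lie close. Here dimethylamino leaves and methyl enters, so carbon is removed rather than added, yet the acceptor also goes. On balance a small downward step or none beyond the scatter is expected, and for compound 4 the expected step is a 1.3-fold lower number from compound 3 to compound 4 (0.12 log units; within the scatter). Compound 4 is therefore estimated at 1500 nM, with a range from 500 nM to 4500 nM.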

Compound 4, solubility: 3000 nM
The estimate for compound 4 lay 2.0-fold (0.30 log units) below the measured number; measured number inside the range.
By their numbers in this assay, from the lowest: compounds 3 and 4 (each within the scatter of the next); then compound 1. At a limit, below all of these: compound 2.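

At the aromatic carbon between two ring nitrogen atoms, this assay does not separate methyl from dimethylamino, with a 1.5-fold higher number from compound 3 to compound 4 (0.18 log units; within the scatter) as the measured step. Against amino, the step is a 3.1-fold lower number from compound 1 to compound 4 (0.49 log units; beyond the scatter) and, like the dimethylamino step before it, lies beyond the scatter, so a group with no nitrogen on this carbon also stands lower than amino among the compounds shown. The value of compound 2 is a limit and not a number, so an at least 3.0-fold higher number from compound 2 to compound 4 (0.47 log units; beyond the scatter) is only a floor, although that floor lies beyond the scatter and sets methylamino apart from methyl at this carbon: the limit of < 1000 nM in this assay, at which 1 of the 4 values shown sits.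

The compounds shown leave open how a methoxy group, a longer chain such as propyl or a cyclic amine such as morpholine would stand at this carbon, and whether any of them would stay with methyl and dimethylamino or reach amino. As far as these compounds go, the number for compound 2 also stays open, and with it any firm comparison of methylamino with dimethylamino on the shared core.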